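Open-chain sulfonamide tail replaces the hydroxypiperidine amide

The source may hold more compounds than are shown below. What is called first, only, known or untested is meant among the compounds shown, and "the series" means these compounds.

Measured so far:
Compound 1, `CC(C)(C)c1ccc(C(=O)N2CCC3(CC2)C(=O)N(CC(=O)N2CCCC(C(N)=O)C2)CN3c2ccccc2)cc1`: 16900 nM
Compound 2, `CC(C)(C)OC(=O)NCCCCNC(=O)CN1CN(c2ccccc2)C2(CCN(C(=O)c3ccc(C(C)(C)C)cc3)CC2)C1=O`: "not determined" (no result reported)
Compound 3, `CC(C)(C)c1ccc(C(=O)N2CCC3(CC2)C(=O)N(CC(=O)N2CCC(O)CC2)CN3c2ccccc2)cc1`: 4700 nM

In an assay on HEK293 cells for displacement of a labelled ligand from NPC1-like intracellular cholesterol transporter 1 (Homo sapiens) (a higher number here means a weaker inhibitor, a lower number a stronger inhibitor), compound 3 gives 4700 nM and stands as the lowest of the two numbers at hand; compound 1 is nearest, and the step of a 3.6-fold lower number from compound 1 to compound 3 (0.56 log units; beyond the scatter) lies beyond the scatter. Compound 2 was prepared but in this assay compound 2 has "not determined" (no result reported), so it adds nothing to the comparison.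

Compound 4, `CC(C)(C)c1ccc(C(=O)N2CCC3(CC2)C(=O)N(CC(=O)NCCCNS(C)(=O)=O)CN3c2ccccc2)cc1`, has yet to be measured in this assay. The change from compound 3 is (3-(methanesulfonamido)propyl)amino in place of 4-hydroxypiperidin-1-yl on a carbonyl carbon. Going by the values given here, the only measured step that bears on this position is a 3.6-fold lower number from compound 1 to compound 3 (0.56 log units; beyond the scatter), which shows that exchanging the group on this carbonyl carbon moves the number by a modest amount. No open-chain amide at this position has a number, so the direction for compound 4 is uncertain; a modest shift, perhaps a slight weakening, is expected, a 1.5-fold higher number from compound 3 to compound 4 (0.17 log units; within the scatter). Compound 4 is therefore estimated at 7000 nM, within a range from 2000 nM to 25000 nM.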

Compound 4, half-maximal inhibitory concentration: 10400 nM
Compound 4: the middle estimate sits 1.5-fold (0.17 log units) below what was measured, within the range that was stated.
By their numbers in this assay, from the lowest: compound 3; then compounds 4 and 1 (each within the scatter of the next).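

In this assay, going by these compounds alone, the first open-chain group on this carbonyl carbon comes with a 2.2-fold higher number from compound 3 to compound 4 (0.34 log units; beyond the scatter) and so does not match the 4-hydroxypiperidin-1-yl group. Against the other ring amide, the same tail gives a 1.6-fold lower number from compound 1 to compound 4 (0.21 log units; within the scatter) and so cannot be told apart from 3-carbamoylpiperidin-1-yl, which means that compound 3 alone stands clear of the other two. No measurement at hand accounts for these differences.

The change removes the ring and brings in the methanesulfonamide at once, so a propyl chain ending in a hydroxyl group, or a piperidine carrying the methanesulfonamide, would be needed to separate the two. From the compounds shown here alone, how this assay would respond to a longer chain, or to a carboxylic acid in place of the methanesulfonamide, also remains open.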